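The compounds below may be only part of what the source reports. "The series", "measured", "known", "first", "only" and "open" are said of these compounds alone.

Measured compounds:
compound 1 `CC[C@]1(c2cccc([N+](=O)[O-])c2)OC[C@H]([C@@H]2CCCCN2)O1` — 1320 nM
compound 2 `NC[C@H]1COC(c2ccccc2)(c2ccccc2)O1` — 1400 nM

In a functional assay (brain) for displacement of a labelled ligand, with Rattus norvegicus as the target (a lower number here means a stronger inhibitor, a higher number a weaker inhibitor), compound 1 gives 1320 nM and compound 2 gives 1400 nM. Of the two numbers, that of compound 2 is nominally the higher, but the gap to compound 1 lies within the scatter, so the two compounds cannot be told apart on these data.

Compound 3 `CCNC[C@H]1COC(c2ccccc2)(c2ccccc2)O1` differs from compound 2 in a single place: ethyl in place of hydrogen on an amine nitrogen. Among the measured compounds shown here, no measured pair shows this change, so nothing is known from these compounds about its effect. For the measured compounds named here, on the single value of compound 2, which is 1400 nM, a step from compound 2 to compound 3 of a 1.3-fold lower number from compound 2 to compound 3 (0.10 log units; within the scatter) is expected, that is, no change beyond the scatter in either direction. Compound 3 is therefore estimated at 1100 nM, with a range from 300 nM to 4000 nM.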

Compound 3, inhibition constant: 8400 nM
Beside the measured number, compound 3's estimate is 7.6-fold (0.88 log units) below it; measured number above the stated range.
By their numbers in this assay, from the lowest: compounds 1 and 2 (each within the scatter of the next); then compound 3.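

Until now nothing was known about substitution on this amine nitrogen, and the pair gives the first reading: in this assay, ethyl in place of hydrogen gives a 6.0-fold higher number from compound 2 to compound 3 (0.78 log units; beyond the scatter), a step beyond the scatter. The nitrogen of the aminomethyl group is therefore a place where a small addition of this kind shows in the number, and the change from amino to ethylamino goes towards weaker inhibition, though this rests on a single pair on a single core. No evidence at hand bears on the origin of this step.

On these data alone, it remains open whether a methyl, a propyl chain or a second ethyl on the same nitrogen would give a step of similar size. Also open, as far as these compounds go, is whether ethyl on the amine nitrogen of compound 1 would act in the same direction.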